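Chloro to Methoxy on the Core: Cytotoxicity Expected Unchanged

The source may hold more compounds than are shown below. What is called first, only, known or untested is meant among the compounds shown, and "the series" means these compounds.

Compound 1 `CCOc1ccccc1NC(=O)CSc1c[nH]c2c(Cl)cccc12` was tested in an ADME assay on HEK-293T cells (Homo sapiens) for cytotoxicity, read by CCK-8 assay, with a stated time of 48 h; a lower number here means that less compound is tolerated, a higher number that more compound is tolerated. In this assay compound 1 gives > 100000 nM, which is a limit of the assay rather than a measured number. Compound 2 `Cn1cc(SCC(=O)Nc2ccc(Cl)c(Cl)c2)c2ccccc21` is built differently in both its core and its amide partner. In this assay compound 2 gives > 100000 nM, again a limit. Both values therefore sit at the limit of > 100000 nM in this assay, at which 2 of the 2 values shown sit, and compound 1 stands nowhere distinct from compound 2 on these numbers.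

Compound 3 `CCOc1ccccc1NC(=O)CSc1c[nH]c2c(OC)cccc12` has not yet been measured in this assay. It differs from compound 1 by one change: methoxy in place of chloro on an aromatic carbon. For the measured compounds named here, no step between two measured compounds is known here, so the data give no direct measure of what this exchange does to cell tolerance. The step expected in this assay from compound 1 to compound 3 is therefore none beyond the scatter, a step that the limit leaves unreadable from compound 1 to compound 3. Compound 3 is estimated at 150000 nM, with a range from 50000 nM to 500000 nM, and it is expected that the assay will again report only a limit.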

Compound 3, half-maximal cytotoxic concentration: > 100000 nM
Compound 3 ended at the assay's limit; the forecaster's own chance of this, stated with the estimate: 85%; the middle value is on the limit's open side.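

Compound 1 and compound 3 both end at a limit in this assay, so no step can be read for methoxy in place of chloro: the limit of > 100000 nM in this assay, at which 3 of the 3 values shown sit.

The compounds shown leave open whether methoxy and chloro on the shared core differ at all in cell tolerance, and at what concentration, if any, these compounds would harm the cells.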